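Chloro in Place of Methyl Across Two Related Cores

A few compounds are considered here, and "the series" means these few. Any claim that something is new, unique, unknown or untested is made for them only; others in the source may bear on it.

Compound 1 `Cc1ccc(NC(=O)CBr)cc1C(=O)NC(N)=O`: 4760 nM
Compound 2 `NC(=O)NC(=O)c1cc(NC(=O)CBr)ccc1Cl`: 540 nM
Compound 3 `Cc1ccc(C(=O)NC(N)=O)cc1NC(=O)C(C)Cl`: only a limit, > 20000 nM

All three were tested in a functional assay on CCRF-CEM cells (Homo sapiens) for antiproliferative activity, read by trypan blue exclusion, with a stated time of 72 h; a lower number here means a stronger inhibitor, a higher number a weaker inhibitor. Compound 1 gives 4760 nM and compound 2 gives 540 nM, so the step of an 8.8-fold lower number from compound 1 to compound 2 (0.95 log units; beyond the scatter) comes from chloro in place of methyl on an aromatic carbon. For compound 3 this assay reports only a limit, > 20000 nM, which sits at the limit of > 20000 nM in this assay, at which 1 of the 3 values shown sits. The difference between the core of compound 3 and that of compound 1 is not broken down here.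

Compound 4 `CC(Cl)C(=O)Nc1cc(C(=O)NC(N)=O)ccc1Cl` is not yet measured. It differs from compound 3 by chloro in place of methyl on an aromatic carbon, the same kind of change as that from compound 1 to compound 2, though the place differs: there the carbon was ortho to a carbamoylcarbamoyl group and para to a ((bromomethyl)carbonyl)amino group, here it is ortho to a ((1-chloroethyl)carbonyl)amino group and para to a carbamoylcarbamoyl group. Going by the values given here, a step like an 8.8-fold lower number from compound 1 to compound 2 (0.95 log units; beyond the scatter) is the only guide, and it starts from a limit, so the expected step from compound 3 is an at least 1.6-fold lower number from compound 3 to compound 4 (0.22 log units; that floor lies within the scatter). Compound 4 is therefore expected near 12000 nM, between 2500 nM and 60000 nM, with a fair chance that this assay again returns only a limit.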

Compound 4, half-maximal inhibitory concentration: > 20000 nM
Compound 4 gave a limit, no number; the forecaster's own chance of this, stated with the estimate: 40%; at least 1.6-fold (0.22 log units) between middle value and limit.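

In this assay, going by these compounds alone, compound 3 and compound 4 both return only a limit, so no step between them can be read. The compounds shown leave open whether chloro in place of methyl changes activity on this core at all.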